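Fluorophenyl changes and tolerated concentration in the series

The source may report more compounds than this note shows. Statements on the series, on what has been measured and on what is new or still open speak of the compounds shown alone.

Measured so far:
- compound 1 `Cc1c(Cc2ccccc2)c(=O)oc2cc(OCC(O)CNn3ccnn3)ccc12`; in an ADME assay on A549 cells (Homo sapiens) for cytotoxicity, read by CellTiter-Glo (a higher number here means that more compound is tolerated, a lower number that less compound is tolerated), compound 1 gives > 100000 nM, a limit of the assay and not a number.
- compound 2 `Cc1c(Cc2ccc(F)cc2)c(=O)oc2cc(OCC(O)CN3CCC(C(N)=O)CC3)ccc12`; in this assay compound 2 gives 89300 nM.
- compound 3 `Cc1c(Cc2cccc(F)c2)c(=O)oc2cc(OCC(O)CN3CCC(C(N)=O)CC3)ccc12`; in this assay compound 3 gives 53300 nM.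

Compound 3 holds the lower of the two numbers shown, but its nearest neighbour compound 2 sits within the scatter of it: a 1.7-fold lower number from compound 2 to compound 3 (0.22 log units; within the scatter). Compound 1 contributes only a limit, (the limit of > 100000 nM in this assay, at which 1 of the 3 values shown sits), so it gives no number to compare against.

The next compound, compound 4 `Cc1cc(F)ccc1Cc1c(C)c2ccc(OCC(O)CN3CCC(C(N)=O)CC3)cc2oc1=O`, is not yet measured. It differs from compound 3 in one place: 4-fluoro-2-methylphenyl in place of 3-fluorophenyl on a saturated chain carbon bound to an aromatic carbon. Going by the values given here, the only measured step of a similar kind is the move of fluorine around the ring between compound 2 and compound 3, which stayed within the scatter. Among the compounds with values here, no step in the set reaches beyond the scatter, so no measured step points to a change of size or direction in this assay for compound 4.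

Compound 4 is therefore expected near compound 3, with a 1.1-fold lower number from compound 3 to compound 4 (0.03 log units; within the scatter) as the estimated step. The estimate for compound 4 is 50000 nM, with a range from 18000 nM to 100000 nM.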

Compound 4, half-maximal cytotoxic concentration: > 100000 nM
Compound 4: a limit, no number; the forecaster's own chance of this, stated with the estimate: 30%; at least 2.0-fold (0.30 log units) between middle value and limit.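

In this assay the value of compound 4 is a limit of the assay and not a number, so this change can be bounded from one side only: the limit of > 100000 nM in this assay, at which 2 of the 4 values shown sit.

Replacing 3-fluorophenyl with 4-fluoro-2-methylphenyl on a saturated chain carbon bound to an aromatic carbon gives an at least 1.8-fold higher number from compound 3 to compound 4 (0.27 log units; that floor lies within the scatter), so even this change involving two substituents on the ring cannot be claimed as a shift in tolerated concentration. Methyl in place of hydrogen on an aromatic carbon, the first change in the set that adds an atom to the fluorophenyl group, gives an at least 1.1-fold higher number from compound 2 to compound 4 (0.04 log units; that floor lies within the scatter), which shows only that this added methyl brings no measurable fall in the tolerated concentration, with its floor again inside the scatter.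

From the compounds shown here alone, the true size of both steps stays open, as does the position of compound 4 relative to the limit. Also open, going by these compounds, is whether the tolerated concentration holds when a trifluoromethyl or a methoxy group stands in place of the added methyl, or when a primary amine or a carboxylic acid stands there instead.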